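Swapping an Aromatic Ring for a Dimethylamino Group

The source may hold more compounds than are shown below. What is called first, only, known or untested is meant among the compounds shown, and "the series" means these compounds.

Compound 1, `Cn1ccn(CC#CCN2CCCC2)c1=O`: 3.7 mg/kg
Compound 2, `Cn1ccn(CC#CCn2ccnc2)c1=O`: 4.5 mg/kg
Compound 3, `Cc1cncn1CC#CCn1ccn(C)c1=O`: 100 mg/kg

These numbers come from a functional assay on the whole organism for agonist activity, with Mus musculus as the target; a higher number here means that more compound is needed for the effect, a lower number that less compound is needed. Compound 2 stands second highest of the three: nearest is compound 1, with a 1.2-fold higher number from compound 1 to compound 2 (0.09 log units; within the scatter), and furthest is compound 3, with a 22-fold higher number from compound 2 to compound 3 (1.35 log units; beyond the scatter).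

Compound 4, `CN(C)CC#CCn1ccn(C)c1=O`, differs from compound 2 in one place: dimethylamino in place of 1H-imidazol-1-yl on a saturated chain carbon bound to a triple-bonded carbon. The step that bears on this is a 1.2-fold higher number from compound 1 to compound 2 (0.09 log units; within the scatter), where pyrrolidin-1-yl gave way to 1H-imidazol-1-yl at the same saturated chain carbon and the number barely moved. The step of a 22-fold higher number from compound 2 to compound 3 (1.35 log units; beyond the scatter) concerns a methyl on an aromatic carbon and does not speak to this change. Going back to a non-ring amine is therefore expected to give no step beyond the scatter, a 1.1-fold lower number from compound 2 to compound 4 (0.05 log units; within the scatter). Compound 4 is expected to give 4 mg/kg, between 1.5 mg/kg and 12 mg/kg.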

Compound 4, dose for half-maximal effect: 5.4 mg/kg
The estimate for compound 4 lay 1.4-fold (0.13 log units) below the measured number, within the range that was stated.
By their numbers in this assay, from the lowest: compounds 1, 2 and 4 (each within the scatter of the next); then compound 3.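

In this assay, dimethylamino, with no ring and fewer heavy atoms, stays within the scatter of both ring groups at this saturated chain carbon, with a 1.2-fold higher number from compound 2 to compound 4 (0.08 log units; within the scatter) and a 1.5-fold higher number from compound 1 to compound 4 (0.16 log units; within the scatter). Across compound 1, compound 2 and compound 4, then, a ring at this place makes no readable difference, though compound 3, with its methyl-bearing ring, goes against this at 100 mg/kg. No measurement available explains why these numbers stay level.

Going by these compounds, whether diethylamino or a hydroxyl group at this carbon would keep the number in the same range remains open.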